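The source may report more compounds than this note shows. Statements on the series, on what has been measured and on what is new or still open speak of the compounds shown alone.

Measured compounds:
compound 1 `Cc1ccc2oc(C)c(C(=O)NCc3ccc(N4CCC(c5ccc(OC(F)(F)F)cc5)CC4)cc3)c2c1` — in a toxicity assay on Vero cells (Chlorocebus sabaeus) for cytotoxicity, read by CCK-8 assay, with a stated time of 72 h (on this read-out higher numbers stand for weaker inhibition and lower numbers for stronger inhibition), compound 1 gives "not determined" (no result reported)
compound 2 `Cc1nc2sccn2c1C(=O)NCc1ccc(N2CCC(c3ccc(OC(F)(F)F)cc3)CC2)cc1` — in this assay compound 2 gives > 100000 nM, which is a limit of the assay and not a number

Compound 1 therefore has no number of its own in this assay; the one figure shown in this assay belongs to compound 2, and it is a limit, as the limit of > 100000 nM in this assay, at which 1 of the 2 values shown sits, records. Compound 3 `Cc1nn2ccsc2c1C(=O)NCc1ccc(N2CCC(c3ccc(OC(F)(F)F)cc3)CC2)cc1` has not yet been measured in this assay. It differs from compound 1 in one place: a group of 9 heavy atoms (6 carbon, 2 nitrogen, 1 sulfur; 2 five-membered aromatic rings with 2 hetero atoms each) in place of a group of 11 heavy atoms (10 carbon, 1 oxygen; one five-membered aromatic ring with 1 hetero atom, one six-membered aromatic ring of carbon only), on a carbonyl carbon. Both compound 2 and compound 3 carry, on the carbonyl carbon, a group of 9 heavy atoms built from 2 five-membered aromatic rings with 2 hetero atoms each in place of the 2,5-dimethyl-1-benzofuran-3-yl group of compound 1, and they share the rest of the structure.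

Among the compounds with values here, with no number for compound 1, no measured step can be drawn, and the direction of any change in this assay from compound 1 to compound 3 cannot be told. The expectation for compound 3 rests on compound 2 alone, whose limit is given by the limit of > 100000 nM in this assay, at which 1 of the 2 values shown sits. Compound 3 is expected to give 100000 nM in this assay, within 30000 nM to 300000 nM, and most likely as a limit rather than a number.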

Compound 3, half-maximal inhibitory concentration: > 100000 nM
Compound 3 gave a limit, no number; the forecaster's own chance of this, stated with the estimate: 70%; the middle value sits exactly at the limit.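

In this assay compound 3 gives > 100000 nM, which is a limit and not a number. Compound 2 gives > 100000 nM, also a limit, so no step can be read between compound 2 and compound 3, and compound 1 has no number to compare. The compounds shown leave open whether the group on the carbonyl carbon changes the half-maximal inhibitory concentration at all: the limit of > 100000 nM in this assay, at which 2 of the 3 values shown sit.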